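The source may report more compounds than this note shows. Statements on the series, on what has been measured and on what is new or still open speak of the compounds shown alone.

Measured so far:
compound 1, `Cc1cc(N2CC[C@@H](C)[C@@H](N(C)c3ncnc4[nH]ccc34)C2)n2nc(SCC3CC3)nc2n1` — in a functional assay on MGC-803 cells (Homo sapiens) for inhibition, read by MTT assay, with a stated time of 72 h (a lower number here means a stronger inhibitor, a higher number a weaker inhibitor), compound 1 gives 9540 nM
compound 2, `Cc1cc(N2CC[C@@H](C)[C@@H](N(C)c3ncnc4[nH]ccc34)C2)n2nc(SCc3ccccc3Br)nc2n1` — compound 2 gives 27000 nM
compound 3, `Cc1cc(N2CC[C@@H](C)[C@@H](N(C)c3ncnc4[nH]ccc34)C2)n2nc(SCCCc3ccccc3)nc2n1` — compound 3 gives only a limit of the assay, > 100000 nM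

Compound 3 stands at the weak end of these three. Going by the values given here, its result is a limit, not a number, and it is the one value among the three that rests at that limit (the limit of > 100000 nM in this assay, at which 1 of the 3 values shown sits). The next compound, compound 4, is `Cc1cc(N2CC[C@@H](C)[C@@H](N(C)c3ncnc4[nH]ccc34)C2)n2nc(SCc3ccc(F)cc3)nc2n1`, and the change from compound 3 is 4-fluorophenyl in place of phenethyl on a saturated chain carbon bound to a sulfur.

Two measured steps end at compound 3 and so bear on this change. The step of an at least 10-fold higher number from compound 1 to compound 3 (1.02 log units; beyond the scatter) and the step of an at least 3.7-fold higher number from compound 2 to compound 3 (0.56 log units; beyond the scatter) both show that the phenethyl group on a saturated chain carbon bound to a sulfur goes with the weakest result here. Compound 2, carrying 2-bromophenyl on a saturated chain carbon bound to a sulfur, gives 27000 nM, and the step of a 2.8-fold higher number from compound 1 to compound 2 (0.45 log units; beyond the scatter) places it only modestly above compound 1. Moving from phenethyl to 4-fluorophenyl is thus expected to bring the number back down from the limit, an expected step of an at least 3.3-fold lower number from compound 3 to compound 4 (0.52 log units; beyond the scatter). Compound 4 is expected to give about 30000 nM, within a range from 10000 nM to 100000 nM.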

Compound 4, half-maximal inhibitory concentration: 11900 nM
For compound 4 the middle estimate is 2.5-fold (0.40 log units) above the measured one; the range from low to high includes it.
By their numbers in this assay, from the lowest: compounds 1 and 4 (each within the scatter of the next); then compound 2. At a limit, above all of these: compound 3.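

In this assay, replacing 3-phenylpropyl with 4-fluorobenzyl on the sulfur gives an at least 8.4-fold lower number from compound 3 to compound 4 (0.92 log units; beyond the scatter), so an aromatic ring at this place does not by itself push the result out of measurable range. The result of compound 3 remains a limit of the assay and not a number: the limit of > 100000 nM in this assay, at which 1 of the 4 values shown sits. The new compound also shows that the ring's substituent can matter, with a 2.3-fold lower number from compound 2 to compound 4 (0.36 log units; beyond the scatter), while a 1.2-fold higher number from compound 1 to compound 4 (0.10 log units; within the scatter) means that 4-fluorophenyl and cyclopropyl cannot be told apart in this series.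

Compound 2 and compound 4 differ both in the halogen and in the printed ring position, so these compounds cannot show which of the two changes accounts for the gap between them. Going by these compounds, it also remains open how a plain benzyl group without a halogen, a 4-chlorobenzyl group or a benzyl group carrying an amine or a carboxylic acid would compare at this place.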